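Cytotoxicity notes: fluoro to trifluoromethoxy on the aryl ring

The compounds below may be only part of what the source reports. "The series", "measured", "known", "first", "only" and "open" are said of these compounds alone.

Measured so far:
- compound 1 `O=[N+]([O-])c1cn2c(n1)OC[C@@H](OCc1ccn(-c3ccc(C(F)(F)F)cc3)n1)C2`: in an ADME assay on Vero cells (Chlorocebus sabaeus) for cytotoxicity, with a stated time of 72 h (on this read-out higher numbers stand for weaker inhibition and lower numbers for stronger inhibition), compound 1 gives > 128000 nM, a limit of the assay.
- compound 2 `O=[N+]([O-])c1cn2c(n1)OC[C@@H](OCc1ccn(-c3ccc(F)cc3)n1)C2`: in this assay compound 2 gives > 128000 nM, also a limit of the assay.

Compound 2 stands only at a limit, with no number of its own; it is one of the two values that sit at the limit of > 128000 nM in this assay, at which 2 of the 2 values shown sit. Among the compounds with values here, the one step measured between the two, a step that the two limits leave unreadable from compound 1 to compound 2, is therefore unreadable and gives no size in either direction.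

Compound 3 `O=[N+]([O-])c1cn2c(n1)OC[C@@H](OCc1ccn(-c3ccc(OC(F)(F)F)cc3)n1)C2` differs from compound 2 by trifluoromethoxy in place of fluoro on an aromatic carbon. Within the data shown here, the only measured step that bears on this place on the ring is unreadable, so no size of step beyond the scatter can be derived for this assay; the expectation is that compound 3 again reaches the limit rather than a readable number.

Compound 3 is expected at 150000 nM, with a range from 60000 nM to 400000 nM. The expected step from compound 2 is a step that the limit leaves unreadable from compound 2 to compound 3, that is, no change readable against the scatter.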

Compound 3, half-maximal inhibitory concentration: > 128000 nM
Compound 3: no number, only a limit (the forecaster's own chance of this, stated with the estimate: 85%); the middle value is on the limit's open side.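

In this assay compound 3 gives only a limit, as do compound 1 and compound 2, so no step among the three can be read: the limit of > 128000 nM in this assay, at which 3 of the 3 values shown sit.

As far as these compounds go, whether the fluoro, trifluoromethyl and trifluoromethoxy compounds differ at all in this read-out remains open.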